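The source may hold more compounds than are shown below. What is called first, only, known or untested is meant among the compounds shown, and "the series" means these compounds.

Compound 1 `COc1cc(NC(=O)Nc2cccc(C)c2)ccc1-c1cnco1`: 320 nM
Compound 2 `COc1cc2nc(-c3ccsc3)cc(O)c2cc1-c1cnco1`: 340 nM

Both values come from a functional assay on CCRF-CEM cells (Homo sapiens) for inhibition; on this read-out lower numbers stand for stronger inhibition and higher numbers for weaker inhibition. Compound 2 stands within the scatter of compound 1, so the two cannot be told apart on these numbers, even though their structures differ in more than one place. Compound 3 `COc1cc2nc(-c3cccc(C)c3)cc(O)c2cc1-c1cnco1` keeps the rest of compound 2 and changes one group: 3-methylphenyl in place of thiophen-3-yl on an aromatic carbon. It has 3-methylphenyl in place of thiophen-3-yl on an aromatic carbon, next to the ring nitrogen. For the measured compounds named here, no measured pair shows what this swap does, so the expectation is loose. The 3-methylphenyl group also occurs in compound 1, at 320 nM, which offers only a weak hint. In this assay, no change beyond the scatter is expected. The expected step, a 1.4-fold lower number from compound 2 to compound 3 (0.13 log units; within the scatter), is small and leans towards a lower number. For compound 3 the estimated value is 250 nM, with an expected range of 80 nM to 800 nM.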

Compound 3, half-maximal inhibitory concentration: 1100 nM
Compound 3: middle estimate off by 4.4-fold (0.64 log units), on the low side, and the stated range ends below it.
By their numbers in this assay, from the lowest: compounds 1 and 2 (each within the scatter of the next); then compound 3.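

In this assay, putting 3-methylphenyl in place of thiophen-3-yl gives a 3.2-fold higher number from compound 2 to compound 3 (0.51 log units; beyond the scatter) and so weakens inhibition. For the compounds shown here, this is the first measured pair to show that the group on this aromatic carbon, next to the ring nitrogen, matters to the read-out, and that the rest of the structure does not make this position indifferent to change. Here a five-membered aromatic ring with a hetero atom gives way to a six-membered aromatic ring of carbon only, and nothing measured here bears on why the number rises.

The pair changes the ring and adds the methyl group in one step, so it leaves open which of the two carries the loss; an unsubstituted phenyl would separate them. On these data alone, how a furan-3-yl or a ring bearing an amine would behave at this position also stays open.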